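Amino for chloro on a purine-type core: second instance

The compounds below may be only part of what the source reports. "The series", "measured", "known", "first", "only" and "open" are said of these compounds alone.

Measured so far, in a functional assay on 786-0 cells (Homo sapiens) for cytotoxicity, read by sulforhodamine B assay, with a stated time of 48 h; on this read-out lower numbers stand for stronger inhibition of growth and higher numbers for weaker inhibition of growth:
compound 1, `Nc1nc(Cl)c2ncn(Cc3ccc(CCl)cc3)c2n1`, 93300 nM
compound 2, `ClCc1cccc(Cn2cnc3c(Cl)nc(Cl)nc32)c1`, 26900 nM
compound 3, `ClCc1ccc(Cn2cnc3c(Cl)nc(Cl)nc32)cc1`, 29500 nM

Compound 2 and compound 3 are built from the same atoms joined differently; the difference between the two cores is not broken down here. Their values in this assay lie within the scatter of each other, so nothing separates them.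

Compound 3 and compound 1 differ by amino in place of chloro on an aromatic carbon. That change gives a 3.2-fold higher number from compound 3 to compound 1 (0.50 log units; beyond the scatter), a modest step toward weaker growth inhibition.

Compound 4, `Nc1nc(Cl)c2ncn(Cc3cccc(CCl)c3)c2n1`, is not yet measured. It stands to compound 2 as compound 1 stands to compound 3: the change is amino in place of chloro on an aromatic carbon, and its place reads the same word for word as in the first pair, so it is the same change on the other core.

For the measured compounds named here, the step expected here is a 3.2-fold higher number from compound 2 to compound 4 (0.50 log units; beyond the scatter), set that way because a 3.2-fold higher number from compound 3 to compound 1 (0.50 log units; beyond the scatter) is the single earlier instance the series gives for this change; one instance is a thin footing, so the range is kept wide.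

For compound 4 the estimate in this assay is 86000 nM, expected to fall between 40000 nM and 180000 nM.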

Compound 4, concentration for total growth inhibition: 26300 nM
Compound 4: the middle estimate sits 3.3-fold (0.51 log units) above what was measured; the measured number lies below the stated range.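

In this assay amino in place of chloro on an aromatic carbon gives little to read on this core (step: a 1.0-fold lower number from compound 2 to compound 4 (0.01 log units; within the scatter)), so here the change leaves no visible mark on growth inhibition. Two pairs cannot show why the result differs between the cores, nor predict the size of the step on any further core, and they offer no rule beyond compounds 1 to 4. What they do show is that the step measured on one core cannot be carried over unchanged to the other in this series, as the two instances disagree: the same change on two cores in this assay, a 3.2-fold higher number (0.50 log units; beyond the scatter) from compound 3 to compound 1 and a 1.0-fold lower number (0.01 log units; within the scatter) from compound 2 to compound 4, 3.2-fold (0.51 log units) apart, beyond the scatter of two such steps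

The compounds shown leave open how a methylamino, hydroxyl or methoxy group would behave in the place taken here by amino, and whether the two cores would part in the same way for those groups. They also leave open whether the same split would persist with a hydroxymethyl group in place of the chloromethyl group.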